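The source may report more compounds than this note shows. Statements on the series, on what has been measured and on what is new or still open speak of the compounds shown alone.

Measured compounds:
compound 1, `O=c1n(Cc2cn(Cc3cc4ccc(Cl)cc4nc3Cl)nn2)cnn1-c1ccccc1`: 869 ug/mL
compound 2, `O=c1n(Cc2cn(Cc3cc4ccccc4nc3Cl)nn2)cnn1-c1ccccc1`: 655 ug/mL

In an ADME assay on HEK293 cells (Homo sapiens) for cytotoxicity, read by MTT assay (on this read-out lower numbers stand for stronger inhibition and higher numbers for weaker inhibition), compound 2 gives 655 ug/mL and compound 1 gives 869 ug/mL, so the two stand within the scatter of each other, as the step of a 1.3-fold lower number from compound 1 to compound 2 (0.12 log units; within the scatter) shows. Compound 3, `COc1ccc2cc(Cn3cc(Cn4cnn(-c5ccccc5)c4=O)nn3)c(Cl)nc2c1`, has not yet been measured in this assay. It differs from compound 2 by methoxy in place of hydrogen on an aromatic carbon. For the measured compounds named here, the only measured step, a 1.3-fold lower number from compound 1 to compound 2 (0.12 log units; within the scatter), concerns a different change on the shared core, a hydrogen in place of chloro, and was within the scatter; no measured pair bears on a methoxy entering at this place. On this basis, compound 3 is expected to give a number close to that of compound 2, with a step of a 1.0-fold lower number from compound 2 to compound 3 (0.00 log units; within the scatter) that stays within the scatter. The estimate for compound 3 in this assay is 650 ug/mL, within a range from 300 ug/mL to 1400 ug/mL.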

Compound 3, half-maximal inhibitory concentration: 1010 ug/mL
The estimate for compound 3 lay 1.6-fold (0.19 log units) below the measured number, within the range that was stated.
By their numbers in this assay, from the lowest: compounds 2, 1 and 3 (each within the scatter of the next).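

Placed on this aromatic carbon in this assay, methoxy gives a 1.5-fold higher number from compound 2 to compound 3 (0.19 log units; within the scatter) and so does not separate itself from hydrogen beyond the scatter. Set against chloro at the same place, it gives a 1.2-fold higher number from compound 1 to compound 3 (0.07 log units; within the scatter) and again stays within the scatter, so hydrogen, chloro and methoxy cannot be told apart here on this read-out, even though methoxy brings an oxygen and a hydrogen-bond acceptor that the other two groups lack. Nothing measured alongside these numbers offers an account of this result.

The three compounds leave open whether an amine, a carboxylic acid or a longer chain on this aromatic carbon would carry the number beyond the scatter. They also leave open whether other places on the shared core respond any differently.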